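A few compounds are considered here, and "the series" means these few. Any claim that something is new, unique, unknown or untested is made for them only; others in the source may bear on it.

In an assay on HEK293 cells for negative allosteric modulation of metabotropic glutamate receptor 5 (Homo sapiens), read by FLIPR, with a stated time of 1 h (a lower number here means a stronger inhibitor, a higher number a weaker inhibitor), compound 1 `CCC(=O)N1CCc2nc(C#Cc3ccccc3)sc2C1` gives 38 nM. Compound 2 `CC1CC1C(=O)N1CCc2nc(C#Cc3ccccc3)sc2C1` reaches only a limit, > 10000 nM, rather than a number (the limit of > 10000 nM in this assay, at which 1 of the 3 values shown sits). Compound 3 `O=C(C1CCC1)N1CCc2nc(C#Cc3ccccc3)sc2C1` gives 370 nM, the higher of the two numbers shown, with compound 1 the nearest, and a 9.7-fold higher number from compound 1 to compound 3 (0.99 log units; beyond the scatter). Compound 4 `COC1CC(C(=O)N2CCc3nc(C#Cc4ccccc4)sc3C2)C1` differs from compound 3 by methoxy in place of hydrogen on a saturated ring carbon. For the measured compounds named here, no measured step adds a group to a ring on the carbonyl carbon; the closest guides are an at least 260-fold higher number from compound 1 to compound 2 (2.42 log units; beyond the scatter) and an at least 27-fold lower number from compound 2 to compound 3 (1.43 log units; beyond the scatter), where a methyl on a smaller ring went with a large loss. A weakening step is therefore expected for compound 4, a 3.2-fold higher number from compound 3 to compound 4 (0.51 log units; beyond the scatter) in this assay. Compound 4 is thus estimated at 1200 nM, between 150 nM and 10000 nM.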

Compound 4, half-maximal inhibitory concentration: > 10000 nM
Compound 4: no number, only a limit (the forecaster's own chance of this, stated with the estimate: 25%); middle value at least 8.3-fold (0.92 log units) away from the limit.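

In this assay compound 4 reaches only a limit, > 10000 nM. Cyclobutyl on the carbonyl carbon still gave a measurable number in compound 3, yet methoxy in place of hydrogen on that ring gives an at least 27-fold higher number from compound 3 to compound 4 (1.43 log units; beyond the scatter), and the whole change from ethyl to 3-methoxycyclobutyl gives an at least 260-fold higher number from compound 1 to compound 4 (2.42 log units; beyond the scatter). Compound 2 and compound 4 both end at a limit, so the step between them cannot be read: the limit of > 10000 nM in this assay, at which 2 of the 4 values shown sit.

As far as these compounds go, whether a hydroxyl or a fluorine on this ring carbon would keep a measurable number stays open. From the compounds shown here alone, how weak compound 4 really is also stays open.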